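This account rests on a few compounds, and the source may have more. Where it says the series, first, only, none or still open, it means among the compounds named here.

Of the compounds shown here, three built on a shared core have been measured so far in a functional assay on COR-L23 cells (Homo sapiens) for antiproliferative activity, read by CellTiter-Glo, with a stated time of 4 days (on this read-out higher numbers stand for weaker inhibition and lower numbers for stronger inhibition), and span a wide range. Compound 1 `O=C(Nc1ccc(CN2C(=O)c3ccccc3C2=O)cc1)[C@H]1C[C@@H]1c1cccnc1` gives 35 nM there, compound 2 `CCC(=O)NC(C)(C)c1ccc(NC(=O)[C@H]2C[C@@H]2c2cccnc2)cc1` gives 2310 nM and compound 3 `CC[C@H](NC(=O)c1ccccc1)c1ccc(NC(=O)[C@H]2C[C@@H]2c2cccnc2)cc1` gives 137 nM as the middle value of the three. Compound 4 `C[C@H](NC(=O)c1ccccc1)c1ccc(NC(=O)[C@H]2C[C@@H]2c2cccnc2)cc1` is still unmeasured. It differs from compound 3 by hydrogen in place of methyl on a saturated chain carbon, two bonds along the chain from an amide-type nitrogen and an aromatic carbon with hydrogen in place of methyl on a saturated chain carbon, two bonds along the chain from an amide-type nitrogen and an aromatic carbon, so that ethyl becomes methyl. Going by the values given here, no measured pair shows this change, and no step beyond the scatter is expected in this assay here. An estimated step of a 1.4-fold lower number from compound 3 to compound 4 (0.14 log units; within the scatter) is expected. For compound 4 the expected value is 100 nM with an estimated range from 35 nM to 300 nM as its limits.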

Compound 4, half-maximal inhibitory concentration: 8 nM
Compound 4: the middle estimate sits 13-fold (1.10 log units) above what was measured, and the stated range ends above it.
By their numbers in this assay, from the lowest: compound 4; then compound 1; then compound 3; then compound 2.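

In this assay, going by these compounds alone, the change from ethyl to methyl on a saturated chain carbon, two bonds along the chain from an amide-type nitrogen and an aromatic carbon, brings a 17-fold lower number from compound 3 to compound 4 (1.23 log units; beyond the scatter) and is the first step read between compounds differing in one place. It shows that removing one carbon at this position can shift the read-out well beyond the scatter. No evidence at hand accounts for the size of this step. The compounds shown leave open how a propyl chain, a hydroxymethyl group or the opposite configuration at this carbon would read.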